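The source may hold more compounds than are shown below. What is called first, only, known or untested is meant among the compounds shown, and "the series" means these compounds.

Compounds measured so far:

- Compound 1, `CCNC(=O)C1=C(C)NC(=O)NC1c1ccco1`: 3%
- Compound 2, `CCN(CC)C(=O)C1=C(C)NC(=O)NC1c1ccco1`: 19%
- Compound 3, `CC1=C(C(N)=O)C(c2ccoc2)NC(=O)N1`: 2%

In an assay on membranes from HeLa cells for displacement of a labelled ligand from adenosine receptor A3 (Homo sapiens), read by scintillation counting, with a stated time of 180 min, tested at 1 uM (on this read-out higher numbers stand for more inhibition at the one concentration tested (going by the name of the read-out) and lower numbers for less inhibition), compound 1 gives 3%, and compound 2 gives 19%. The two differ in one place: ethyl in place of hydrogen on an amide-type nitrogen. That change brings a number 16 percentage points higher from compound 1 to compound 2 (beyond the scatter). Compound 3 gives 2% in this assay; its number and that of compound 1 lie within the scatter of each other, so nothing can be said about which of the two is higher. Compound 3 carries a core of its own, and the difference between the two cores is not broken down here.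

Compound 4, `CCNC(=O)C1=C(C)NC(=O)NC1c1ccoc1`, has not yet been measured in this assay. It is derived from compound 3 by the change (ethyl in place of hydrogen on an amide-type nitrogen). Among the measured compounds shown here, this is the same kind of change as the one that led from compound 1 to compound 2, but not the same: in compound 1 the amide-type nitrogen already has a carbonyl carbon and a saturated chain carbon as its other neighbours, whereas in compound 3 its only other neighbour is a carbonyl carbon. So in compound 4 the nitrogen ends up with one ethyl and one hydrogen, as in compound 1, not with two ethyl groups as in compound 2. Because compound 1 gives 3% with exactly that arrangement, a small step is expected from compound 3 to compound 4, a number 4 percentage points higher from compound 3 to compound 4 (within the scatter), well short of the earlier one. For compound 4 a value of 6% is estimated, expected to lie between -5% and 18%.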

Compound 4, a percentage reported as inhibition, at one concentration (the size of the read-out at that concentration, not a potency): 1%
Compound 4: the middle estimate sits 5 percentage points above what was measured, and the stated range covers the measured number.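

In this assay, ethyl in place of hydrogen on the amide-type nitrogen of compound 3 brings a number 1 percentage points lower from compound 3 to compound 4 (within the scatter), and furan-3-yl in place of furan-2-yl brings a number 2 percentage points lower from compound 1 to compound 4 (within the scatter), so neither change stands out from the scatter of this measurement. The ethyl change therefore does not carry over with the same size from one core to the other: the same change on two cores in this assay, a number 16 percentage points higher (beyond the scatter) from compound 1 to compound 2 and a number 1 percentage points lower (within the scatter) from compound 3 to compound 4, 17 percentage points apart, beyond the scatter of two such steps

Among the compounds shown here, this comparison rests on only two steps, and it does not show why they differ or give a rule for other cores, since the nitrogen ends with two ethyl groups in one step and with one ethyl and one hydrogen in the other.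

The compounds shown leave open whether a second ethyl on the nitrogen of compound 4 would bring a step like the one seen on the core of compound 1, and how a longer chain such as propyl would read at that nitrogen. They also leave open what an amine or a carboxylic acid would do in place of the furan groups.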